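Trading bromo for methoxy on a benzyl group

This account rests on a few compounds, and the source may have more. Where it says the series, first, only, none or still open, it means among the compounds named here.

In a functional assay on HL-60 cells (Homo sapiens) for antiproliferative activity, with a stated time of 72 h (on this read-out lower numbers stand for stronger inhibition and higher numbers for weaker inhibition), compound 1 `OC[C@H]1O[C@@H](n2cnc3c(NCc4cccc(F)c4)ncnc32)[C@H](O)[C@@H]1O` gives 920 nM and compound 2 `OC[C@H]1O[C@@H](n2cnc3c(NCc4ccccc4Br)ncnc32)[C@H](O)[C@@H]1O` gives 6600 nM. Compound 2 therefore has the higher of the two actual numbers and is the weaker inhibitor of this pair. For compound 3 `Cc1ccc(CNc2ncnc3c2ncn3[C@@H]2O[C@H](CO)[C@@H](O)[C@H]2O)cc1`, the result is only a limit, > 166000 nM.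

Compound 4 `COc1ccccc1CNc1ncnc2c1ncn2[C@@H]1O[C@H](CO)[C@@H](O)[C@H]1O` differs from compound 2 by methoxy in place of bromo on an aromatic carbon, ortho to a large group: methoxy in place of bromo on an aromatic carbon. The relevant measured steps all alter the aromatic group on the same chain carbon. The change of a 7.2-fold higher number from compound 1 to compound 2 (0.86 log units; beyond the scatter) is modest, while those of an at least 180-fold higher number from compound 1 to compound 3 (2.25 log units; beyond the scatter) and an at least 25-fold higher number from compound 2 to compound 3 (1.40 log units; beyond the scatter) are large, so this part of the molecule can clearly shift the number. None of these steps swaps bromo for methoxy, however, and both direction and size remain uncertain. Compound 4 keeps its new group in the place held by bromo in compound 2, so no step beyond the scatter is expected. In this assay, the estimated change is a 1.2-fold higher number from compound 2 to compound 4 (0.08 log units; within the scatter). For compound 4, the estimated value is 8000 nM, with an expected range of 1500 nM to 50000 nM.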

Compound 4, half-maximal inhibitory concentration: 2300 nM
The estimate for compound 4 lay 3.5-fold (0.54 log units) above the measured number; measured number inside the range.
By their numbers in this assay, from the lowest: compound 1; then compound 4; then compound 2. At a limit, above all of these: compound 3.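

In this assay, methoxy in place of bromo on this aromatic carbon is a real change, not a neutral swap: a 2.9-fold lower number from compound 2 to compound 4 (0.46 log units; beyond the scatter). The 2-methoxyphenyl group still does not match the 3-fluorophenyl group, with a 2.5-fold higher number from compound 1 to compound 4 (0.40 log units; beyond the scatter), so a group on this carbon can improve on bromo without making compound 4 the best of the measured set. Exchanging 4-methylphenyl for 2-methoxyphenyl gives an at least 72-fold lower number from compound 3 to compound 4 (1.85 log units; beyond the scatter), a gap that rests on compound 3 having only a limit of the assay: the limit of > 166000 nM in this assay, at which 1 of the 4 values shown sits.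

The compounds shown leave open whether the gain comes from the oxygen of methoxy or simply from a group of two heavy atoms at this place. A comparison with ethyl, hydroxy or an amine on the same carbon could help separate these possibilities.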